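The source may report more compounds than this note shows. Statements on the series, on what has been measured and on what is new or still open speak of the compounds shown alone.

Measured in a functional assay on MT4 cells (Homo sapiens) for cytotoxicity; on this read-out higher numbers stand for lower toxicity in this test and lower numbers for higher toxicity in this test:
- Compound 1 `CCC(C)Sc1nc(O)c(C)c(Cc2c(F)cccc2F)n1`: 200000 nM
- Compound 2 `CC(C)CSc1nc(O)cc(C(C)c2c(F)cccc2F)n1`: > 200000 nM

For the measured compounds named here, only two readings exist so far, and they tell little about how structure shapes toxicity in cells. Going by the values given here, compound 1 holds the only true number, 200000 nM. Compound 2 is reported as > 200000 nM, which is a limit of the assay and not a number. Among the compounds with values here, this leaves no measured step between compounds to use as a guide.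

The next compound to be tested is compound 3 `CCC(C)Sc1nc(O)c(C)c(C(C)c2c(F)cccc2F)n1`. It is built from compound 1 by one small edit: methyl in place of hydrogen on a saturated chain carbon bound to two aromatic carbons. In plain terms, this puts methyl in place of hydrogen on a saturated chain carbon bound to two aromatic carbons.

Within the data shown here, with no measured step to draw on, the starting point is compound 1 at 200000 nM, and no change beyond the usual scatter is expected in this assay. The expected size of the move is a 1.1-fold lower number from compound 1 to compound 3 (0.05 log units; within the scatter). The assay may well report only a limit here. For compound 3 the estimated value is 180000 nM, with an expected range from 70000 nM to 300000 nM.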

Compound 3, half-maximal cytotoxic concentration: > 200000 nM
Compound 3: only a limit was reported; the forecaster's own chance of this, stated with the estimate: 55%; middle value at least 1.1-fold (0.04 log units) from the limit.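

In this assay, methyl in place of hydrogen on a saturated chain carbon bound to two aromatic carbons gives a number no lower from compound 1 to compound 3 (the limit leaves the size open). The reading for compound 3, > 200000 nM, is a limit of the assay and not a number, so this small addition at this position brings no sign of greater toxicity in these cells, while the true size of the move stays hidden. The read-out can say little more about this change because of where the values sit: the limit of > 200000 nM in this assay, at which 2 of the 3 values shown sit.

What the compounds shown leave open is whether any group on this carbon would shift toxicity to a value that can be read as a true number, for example an ethyl chain, a hydroxyl or an amine. Also open, from the compounds shown here alone, is how far the toxicity of compound 3 really lies from that of compound 1, since a limit cannot settle it.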